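Aryl swap on the ring nitrogen: compound 4 expected

A few compounds are considered here, and "the series" means these few. Any claim that something is new, unique, unknown or untested is made for them only; others in the source may bear on it.

Measured compounds:
Compound 1 `Nc1scc(CN2CCN(c3cccc(Cl)c3Cl)CC2)c1C(=O)c1ccc(Cl)cc1` gives 2% in an assay on CHO cells for displacement of a labelled ligand from adenosine receptor A1 (Homo sapiens), read by scintillation counting, with a stated time of 120 min, tested at 10 uM; a higher number here means more inhibition at the concentration tested (going by the name of the read-out), a lower number less inhibition.
Compound 2 `Nc1scc(CN2CCN(c3cc(Cl)cc(Cl)c3)CC2)c1C(=O)c1ccc(Cl)cc1` gives 1% in this assay.
Compound 3 `Nc1scc(CN2CCN(c3ccc(C(F)(F)F)cc3)CC2)c1C(=O)c1cccc(C(F)(F)F)c1` gives 0% in this assay.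

All three compounds share a core and differ in the aryl group on the amine nitrogen in the ring. Compound 3 has the smallest of the three numbers, but the gaps to compound 2 and to compound 1 lie within the scatter, so none of the three can be set apart from the others in this assay.

Compound 4 `Nc1scc(CN2CCN(c3c(F)cccc3F)CC2)c1C(=O)c1cccc(C(F)(F)F)c1` is the compound not yet measured. It differs from compound 3 in one place: 2,6-difluorophenyl in place of 4-(trifluoromethyl)phenyl on an amine nitrogen in a ring.

For the measured compounds named here, one measured step bears on this change, since it also alters the aryl group on the same ring nitrogen: a number 1 percentage points lower from compound 1 to compound 2 (within the scatter). That swap left the number essentially unchanged, and every aryl variant tried so far gave a number near zero. Nothing measured points to the aryl group on the ring nitrogen mattering in this assay.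

For compound 4, no step beyond the scatter is expected, so a number 2 percentage points higher from compound 3 to compound 4 (within the scatter) is the estimated change. Compound 4 is therefore expected to give 2%, with a likely range from -6% to 10%.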

Compound 4, a percentage reported as inhibition, at one concentration (the size of the read-out at that concentration, not a potency): 0%
Estimate against measurement, compound 4: 2 percentage points above; measured number inside the range.
By their numbers in this assay, from the lowest: compounds 3, 4, 2 and 1 (each within the scatter of the next).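

In this assay, replacing 4-(trifluoromethyl)phenyl with 2,6-difluorophenyl gives no change at the digits printed from compound 3 to compound 4 (within the scatter), so a second, quite different aryl swap on this ring nitrogen also stays within the scatter. Unlike the earlier step, which exchanged one dichlorophenyl group for another, this one changes the kind of halogen-bearing substituent and takes the group from 10 heavy atoms to 8, and it does so with a different aryl group on the carbonyl. Nothing measured here accounts for the lack of a detectable step.

With compound 3 and compound 4 both at the bottom of the range in this assay, these two compounds cannot show whether this position has any influence on the read-out, since a group that lowered the number further would be hard to see. From the compounds shown here alone, it remains open whether a non-aryl group on this nitrogen, such as a butyl chain, or an aryl ring carrying an amine or a carboxylic acid, would give a number clearly above the scatter.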